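Series notes: methoxy in place of methyl, compound 3

The source may report more compounds than this note shows. Statements on the series, on what has been measured and on what is new or still open speak of the compounds shown alone.

Compound 1 `O=C(Nc1ccc(-n2ncc3c(C(F)(F)F)cccc32)cc1)Nc1ccc(Cl)c(C(F)(F)F)c1` and compound 2 `Cc1cccc2c1cnn2-c1ccc(NC(=O)Nc2ccc(Cl)c(C(F)(F)F)c2)cc1` share one core and differ only in a group on the fused ring system. In a functional assay on LoVo cells (Homo sapiens) for cytotoxicity, read by MTT assay, with a stated time of 72 h (on this read-out lower numbers stand for stronger inhibition and higher numbers for weaker inhibition), compound 1 gives 3000 nM and compound 2 gives 3900 nM; the step of a 1.3-fold higher number from compound 1 to compound 2 (0.11 log units; within the scatter) leaves the two level. Going by the values given here, of the two numbers so far, compound 2 has the higher one, but the gap to compound 1 is within the scatter.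

Compound 3 `COc1cccc2c1cnn2-c1ccc(NC(=O)Nc2ccc(Cl)c(C(F)(F)F)c2)cc1` carries the change (methoxy in place of methyl on an aromatic carbon), on an aromatic carbon of a six-membered aromatic ring of carbon only within the fused system. Among the compounds with values here, no measured step covers this exchange; the one step on that ring, a 1.3-fold higher number from compound 1 to compound 2 (0.11 log units; within the scatter), lay within the scatter. For this assay a step no larger than the scatter is therefore expected, with no direction favoured. Compound 3 is expected at 3500 nM, in the range 1500 nM to 8000 nM. The expected step of a 1.1-fold lower number from compound 2 to compound 3 (0.05 log units; within the scatter) thus stays within the scatter.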

Compound 3, half-maximal inhibitory concentration: > 32000 nM
Compound 3: only a limit was reported; the forecaster's own chance of this, stated with the estimate: 5%; middle value at least 9.1-fold (0.96 log units) from the limit.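

Compound 3 is reported only as a limit in this assay: the limit of > 32000 nM in this assay, at which 1 of the 3 values shown sits.

This position, on an aromatic carbon of a six-membered aromatic ring of carbon only, is not indifferent to its group: compound 1 and compound 2 stand within the scatter of each other, whereas methoxy gives an at least 8.2-fold higher number from compound 2 to compound 3 (0.91 log units; beyond the scatter) and an at least 10-fold higher number from compound 1 to compound 3 (1.02 log units; beyond the scatter). The level result for trifluoromethyl and methyl therefore does not extend to every small group on this carbon.

As far as these compounds go, because compound 3 carries only a limit, the true size of both steps stays unknown. The compounds shown also leave open whether the oxygen of methoxy or its second heavy atom goes with the weaker read-out, a question on which a hydroxyl group or an ethyl group on the same carbon would bear.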